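Removing a Methyl from an Amide Nitrogen in a Macrocycle

The source may hold more compounds than are shown below. What is called first, only, known or untested is meant among the compounds shown, and "the series" means these compounds.

Measured compounds:
Compound 1 `CO[C@@H]1C[C@@H]2O[C@@]2(C)C(=O)N(C)[C@@H](C(C)C)C(=O)N[C@H](Cc2cc(Cl)c(O)c(Cl)c2)C(=O)N[C@@H](C(C)(C)O)C(=O)O[C@H](c2ccccc2)[C@H](C)/C=C/C=C/1C`: 6.7 nM
Compound 2 `CC/C1=C\C=C\[C@@H](C)[C@@H](c2ccccc2)OC(=O)[C@H](C(C)C)NC(=O)[C@@H](Cc2cc(Cl)c(O)c(Cl)c2)NC(=O)[C@H](C(C)C)N(C)C(=O)/C(C)=C/C[C@H]1OC`: 60.3 nM
Compound 3 `CC[C@H](C)[C@H]1C(=O)N[C@H](Cc2cc(Cl)c(O)c(Cl)c2)C(=O)N[C@@H](C(C)(C)O)C(=O)O[C@H](c2ccccc2)C/C=C/C=C(\C)[C@H](OC)C[C@@H]2O[C@@]2(C)C(=O)N1C`: 78.2 nM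

The three compounds share a large ring built from amide and ester links and were tested in a functional assay on HCT-116 cells (Homo sapiens) for antiproliferative activity, read by MTT assay, with a stated time of 72 h; on this read-out higher numbers stand for weaker inhibition and lower numbers for stronger inhibition. Compound 1 gives the lowest number of the three; compound 2 and compound 3 both sit well beyond the usual scatter above it, so compound 1 is the most potent of the set.

The unmeasured compound 4 `CO[C@@H]1C[C@@H]2O[C@@]2(C)C(=O)N[C@@H](C(C)C)C(=O)N[C@H](Cc2cc(Cl)c(O)c(Cl)c2)C(=O)N[C@@H](C(C)(C)O)C(=O)O[C@H](c2ccccc2)[C@H](C)/C=C/C=C/1C` differs from compound 1 in a single spot: hydrogen in place of methyl on an amide-type nitrogen in a ring. Within the data shown here, no pair of measured compounds shows this particular change, so its effect cannot be read directly from the numbers at hand. The change is small in atom count, but it sits on a ring nitrogen of the core, and such amide positions often matter for how the ring folds. For compound 4 the step of a 2.2-fold higher number from compound 1 to compound 4 (0.35 log units; beyond the scatter) is expected to be a modest rise, possibly no larger than the scatter. Compound 4 is estimated at 15 nM, within a range of 4 nM to 60 nM.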

Compound 4, half-maximal inhibitory concentration: "not active" (no number reported)
No number was reported for compound 4, and the estimate cannot be compared.
By their numbers in this assay, from the lowest: compound 1; then compounds 2 and 3 (each within the scatter of the next).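

In this assay, among these compounds, compound 4 is reported as "not active" without a number, and no step from compound 1 to compound 4 can be read. Nothing shown here accounts for this result. The compounds shown leave open how large the change from methyl to hydrogen on that amide nitrogen is in this assay.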